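Chloro for trifluoromethyl on the pendant phenyl ring

The source may report more compounds than this note shows. Statements on the series, on what has been measured and on what is new or still open speak of the compounds shown alone.

Measured compounds:
compound 1, `COc1ccc(-c2ccnc(C(=O)Nc3ccc(Oc4ccnc5[nH]ccc45)cc3)c2)cc1`, 9620 nM
compound 2, `O=C(Nc1ccc(Oc2ccnc3[nH]ccc23)cc1)c1cc(-c2ccc(C(F)(F)F)cc2)ccn1`, 14200 nM

Two compounds share a core and differ only in the group on the outer phenyl ring. In a functional assay on PC-3 cells (Homo sapiens) for cytotoxicity, read by MTT assay, with a stated time of 72 h (on this read-out higher numbers stand for weaker inhibition and lower numbers for stronger inhibition), compound 1 gives 9620 nM and compound 2 gives 14200 nM; the change a 1.5-fold higher number from compound 1 to compound 2 (0.17 log units; within the scatter) lies within the scatter, so compound 2 stands with the higher of two numbers that cannot be told apart. Compound 3, `O=C(Nc1ccc(Oc2ccnc3[nH]ccc23)cc1)c1cc(-c2ccc(Cl)cc2)ccn1`, has not yet been measured in this assay. It differs from compound 2 by chloro in place of trifluoromethyl on an aromatic carbon, placed para to a large group on the six-membered aromatic ring of carbon only. Among the compounds with values here, the one measured step bearing on this position, a 1.5-fold higher number from compound 1 to compound 2 (0.17 log units; within the scatter), stayed within the scatter, so no step beyond the scatter is expected here either. Compound 3 is therefore expected to give about 11000 nM in this assay, from 4000 nM to 30000 nM, a step of a 1.3-fold lower number from compound 2 to compound 3 (0.11 log units; within the scatter).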

Compound 3, half-maximal inhibitory concentration: 25100 nM
Compound 3: middle estimate off by 2.3-fold (0.36 log units), on the low side; measured number inside the range.
By their numbers in this assay, from the lowest: compounds 1, 2 and 3 (each within the scatter of the next, the first and the last beyond it).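

In this assay, chloro in place of trifluoromethyl gives a 1.8-fold higher number from compound 2 to compound 3 (0.25 log units; within the scatter), so this change, like the earlier trifluoromethyl for methoxy change, cannot be told apart from the usual scatter. Within the data shown here, the new information comes from the other pair: chloro in place of methoxy gives a 2.6-fold higher number from compound 1 to compound 3 (0.42 log units; beyond the scatter), the first step at this position to clear the scatter, though only modestly, and it shows that the choice of group here can weaken the read-out to a small degree. No measurement is at hand to explain this difference between methoxy and chloro. Still open, going by these compounds, is whether an amine, a carboxylic acid or a longer chain in this place would shift the number further, and in which direction. The compounds shown also leave open whether any group here could give a markedly lower number than compound 1 does.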